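Dichlorophenyl for trifluoromethylphenyl on the shared core

The compounds below may be only part of what the source reports. "The series", "measured", "known", "first", "only" and "open" are said of these compounds alone.

Compound 3 `C=CCn1c(=O)/c(=C\c2ccccc2C(F)(F)F)[nH]c(=O)/c1=C\c1ccccc1OC` gives 9500 nM in a functional assay on Huh-7 cells (Homo sapiens) for cytotoxicity, read by CCK-8 assay, with a stated time of 72 h (a lower number here means a stronger inhibitor, a higher number a weaker inhibitor), the second highest of the three numbers. Compound 1 `C=CCn1c(=O)/c(=C\c2cccc(F)c2)[nH]c(=O)/c1=C\c1ccccc1OC` gives 27200 nM and compound 2 `C=CCn1c(=O)/c(=C\c2cccc(Br)c2)[nH]c(=O)/c1=C\c1ccccc1OC` gives 2300 nM in this assay. Compound 4 `C=CCn1c(=O)/c(=C\c2cccc(Cl)c2Cl)[nH]c(=O)/c1=C\c1ccccc1OC` differs from compound 3 in one place: 2,3-dichlorophenyl in place of 2-(trifluoromethyl)phenyl on a double-bonded chain carbon bound to an aromatic carbon. Among the compounds with values here, two measured steps bear on this. The step of a 12-fold lower number from compound 1 to compound 2 (1.07 log units; beyond the scatter) shows a heavier halogen on that ring giving a markedly lower number, and the step of a 4.1-fold higher number from compound 2 to compound 3 (0.62 log units; beyond the scatter) shows the halogenated ring ahead of the trifluoromethyl ring. A modest move toward a lower number is therefore expected for compound 4, estimated at a 2.7-fold lower number from compound 3 to compound 4 (0.43 log units; beyond the scatter). The estimated value of compound 4 is 3500 nM, with a range from 1200 nM to 10000 nM.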

Compound 4, half-maximal inhibitory concentration: 1200 nM
Beside the measured number, compound 4's estimate is 2.9-fold (0.46 log units) above it; the range from low to high includes it.
By their numbers in this assay, from the lowest: compounds 4 and 2 (each within the scatter of the next); then compound 3; then compound 1.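

At this position on a double-bonded chain carbon, 2,3-dichlorophenyl stands well clear in this assay of the 2-(trifluoromethyl)phenyl ring (a 7.9-fold lower number from compound 3 to compound 4 (0.90 log units; beyond the scatter)) and further still of the 3-fluorophenyl ring (a 23-fold lower number from compound 1 to compound 4 (1.36 log units; beyond the scatter)). Against 3-bromophenyl the change cannot be told from scatter (a 1.9-fold lower number from compound 2 to compound 4 (0.28 log units; within the scatter)), so one bromo and two chloro substituents give matching numbers on this shared core. No measurement given here accounts for these differences.

Still open, as far as these compounds go, is whether a ring with a single chloro would match these two, and whether a ring carrying an amine or a carboxylic acid would keep this level.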